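This account rests on a few compounds, and the source may have more. Where it says the series, first, only, none or still open, it means among the compounds named here.

Measured in a functional assay on CCRF-CEM cells (Homo sapiens) for inhibition, read by MTT assay, with a stated time of 72 h; on this read-out higher numbers stand for weaker inhibition and lower numbers for stronger inhibition:
- Compound 1 `COc1cc(NC(C)CCCNC(=O)NNC(=O)Nc2ccc(F)cc2)c2ncccc2c1`: 118000 nM
- Compound 2 `COc1cc(NC(C)CCCNC(=O)NNC(=O)Nc2ccc(Cl)cc2)c2ncccc2c1`: 108000 nM
- Compound 3 `COc1cc(NC(C)CCCNC(=O)NNC(=O)Nc2ccc(Br)cc2)c2ncccc2c1`: 110000 nM

These three compounds share one core and one chain and differ only in the halogen on the aromatic ring. Compound 3 cannot be separated from the other two on these numbers. The measured steps are a 1.0-fold higher number from compound 2 to compound 3 (0.01 log units; within the scatter), a 1.1-fold lower number from compound 1 to compound 3 (0.03 log units; within the scatter) and a 1.1-fold lower number from compound 1 to compound 2 (0.04 log units; within the scatter), and each lies within the scatter.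

Compound 4 `COc1cc(NC(C)CCCNC(=O)Nc2ccc(C(F)(F)F)cc2)c2ncccc2c1` departs from this series in a much larger way. In it, 4-(trifluoromethyl)phenyl stands in place of ((4-bromophenyl)carbamoyl)amino on an amide-type nitrogen: 4-(trifluoromethyl)phenyl in place of ((4-bromophenyl)carbamoyl)amino on an amide-type nitrogen.

The measured steps bear on this change only weakly. They show that exchanging one halogen for another left the number unmoved, but none of them touches the part of the chain that is removed here. The data therefore give no direct measure of this step. A real step beyond the scatter is nevertheless expected, towards a lower number, and this is a judgement with wide uncertainty rather than a measured trend.

The expected size of the step is a 4.4-fold lower number from compound 3 to compound 4 (0.64 log units; beyond the scatter). For compound 4 the estimated value is 25000 nM, with an expected range from 6000 nM to 90000 nM.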

Compound 4, half-maximal inhibitory concentration: 14000 nM
Compound 4: middle estimate off by 1.8-fold (0.25 log units), on the high side; measured number inside the range.
By their numbers in this assay, from the lowest: compound 4; then compounds 2, 3 and 1 (each within the scatter of the next).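

In this assay, putting 4-(trifluoromethyl)phenyl on the amide-type nitrogen in place of the ((4-halophenyl)carbamoyl)amino groups gives a 7.9-fold lower number from compound 3 to compound 4 (0.90 log units; beyond the scatter), a 7.7-fold lower number from compound 2 to compound 4 (0.89 log units; beyond the scatter) and an 8.4-fold lower number from compound 1 to compound 4 (0.93 log units; beyond the scatter), and all three steps lie beyond the scatter. This shows that the part of the molecule attached at this nitrogen can move the number, whereas the exchanges among fluoro, chloro and bromo had not moved it beyond the scatter; the leaving groups carry hydrogen-bond donors and an acceptor, and the entering group carries neither. No supporting measurement is available to explain why this replacement gives a lower number.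

The single replacement alters both the connection to the aromatic ring and the ring substituent, so the compounds shown leave open how much of the step belongs to each: a 4-bromophenyl group directly on the same nitrogen, or a ((4-(trifluoromethyl)phenyl)carbamoyl)amino group, would separate the two. They also leave open whether another substituent on that ring, such as a nitrile, a methoxy group or an amine, would give a number close to that of compound 4.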